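The source may hold more compounds than are shown below. What is called first, only, known or untested is meant among the compounds shown, and "the series" means these compounds.

Measured compounds:
Compound 1 `CCOC(=O)COc1ccc2c(c1)B(O)OC2`. In an ADME assay on L929 cells (Mus musculus) for cytotoxicity, with a stated time of 72 h (on this read-out lower numbers stand for stronger inhibition and higher numbers for weaker inhibition), compound 1 gives > 10 ug/mL, a limit of the assay.
Compound 2 `COC(=O)COc1ccc2c(c1)B(O)OC2`. In this assay compound 2 gives > 10 ug/mL, a limit of the assay.
Compound 3 `CCC(Oc1ccc2c(c1)B(O)OC2)C(C)=O`. In this assay compound 3 gives > 10 ug/mL, a limit of the assay.

All three values sit at the limit of > 10 ug/mL in this assay, at which 3 of the 3 values shown sit. From compound 2 to compound 1 the change is methyl in place of hydrogen on a saturated chain carbon bound to an oxygen next to a carbonyl group, and the step is a step that the two limits leave unreadable from compound 2 to compound 1. The difference between the core of compound 2 and the core of compound 3 is not broken down here. Compound 4 `CC(=O)C(Oc1ccc2c(c1)B(O)OC2)C(C)C` is not yet measured; it differs from compound 3 by methyl in place of hydrogen on a saturated chain carbon bound to two saturated chain carbons. This is the same kind of change as that from compound 2 to compound 1, but the place differs: there the methyl enters on a saturated chain carbon bound to an oxygen next to a carbonyl group, here on a saturated chain carbon bound to two saturated chain carbons. The step that the limit leaves unreadable from compound 3 to compound 4 is expected to be small, since the earlier step that the two limits leave unreadable from compound 2 to compound 1 left both of its compounds at the limit. Compound 4 is expected to give 15 ug/mL in this assay, most likely again reported only as a limit, within 7 ug/mL to 40 ug/mL.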

Compound 4, half-maximal inhibitory concentration: > 10 ug/mL
Compound 4: only a limit was reported; the forecaster's own chance of this, stated with the estimate: 80%; the middle value is on the limit's open side.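

Compound 4 gives > 10 ug/mL in this assay, a limit of the assay, so no new step can be read between compound 3 and compound 4. The compounds shown leave open where any true value lies, since all stand at the limit: the limit of > 10 ug/mL in this assay, at which 4 of the 4 values shown sit.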